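This account rests on a few compounds, and the source may have more. Where it says the series, first, only, none or still open, it means among the compounds named here.

Compound 1 `O=C(CCl)Nc1cccc(-c2nc3ccccc3s2)c1` and compound 2 `CC(C)(CCl)C(=O)Nc1cccc(-c2nc3ccccc3s2)c1` share one core and differ only in the group on the carbonyl carbon. In an ADME assay on HEK293 cells (Homo sapiens) for inhibition, with a stated time of 72 h (a lower number here means that less compound is needed, a higher number that more compound is needed for the effect), compound 1 gives 10000 nM. For compound 2 this assay reports only a limit, > 25000 nM. The step of an at least 2.5-fold higher number from compound 1 to compound 2 (0.39 log units; beyond the scatter) therefore shows a weaker effect, and the limit of > 25000 nM in this assay, at which 1 of the 2 values shown sits, leaves its true size open. Compound 3 `O=C(Nc1cccc(-c2nc3ccccc3s2)c1)c1cccnc1Cl` carries 2-chloropyridin-3-yl in place of 1-(chloromethyl)-1-methylethyl on a carbonyl carbon. Within the data shown here, only that one measured step bears on this change, and it ran toward higher numbers. The estimated step of a number no higher from compound 2 to compound 3 (the limit leaves the size open) stays within the scatter. Compound 3 is expected to give 25000 nM, likely between 8000 nM and 60000 nM.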

Compound 3, half-maximal effective concentration: > 25000 nM
Compound 3: no number, only a limit; the forecaster's own chance of this, stated with the estimate: 70%; the middle value sits exactly at the limit.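

In this assay, an aromatic ring group on the carbonyl carbon, 2-chloropyridin-3-yl in place of chloromethyl, gives an at least 2.5-fold higher number from compound 1 to compound 3 (0.39 log units; beyond the scatter). The shift to a higher number at this position is therefore not confined to the branched 1-(chloromethyl)-1-methylethyl group. The step between compound 2 and compound 3 cannot be read, and how far either compound lies from compound 1 stays unknown, as both values are limits: the limit of > 25000 nM in this assay, at which 2 of the 3 values shown sit.

Still open, on these data alone, is whether any group here gives a lower number than compound 1, for example an amine or a longer chain ending in chlorine.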